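The source may report more compounds than this note shows. Statements on the series, on what has been measured and on what is new or still open speak of the compounds shown alone.

Of the compounds shown here, three have been tested in an assay on HEK293 cells for displacement of a labelled ligand from 5-hydroxytryptamine receptor 6 (Homo sapiens); on this read-out higher numbers stand for weaker inhibition and lower numbers for stronger inhibition. Compound 1 `CS(=O)(=O)Nc1cccc(S(=O)(=O)N2CCOc3c(N4CCNCC4)cccc32)c1` gives 200 nM and compound 2 `CS(=O)(=O)c1ccccc1S(=O)(=O)N1CCOc2c(N3CCNCC3)cccc21` gives 316 nM. Compound 3 `O=S(=O)(c1cccc2cccnc12)N1CCOc2c(N3CCNCC3)cc(Cl)cc21` gives 0.631 nM, the lowest of the three numbers, and its gaps to compound 1 and to compound 2 both lie well beyond the usual scatter, so compound 3 is the strongest binder among the three.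

Compound 4 `O=S(=O)(c1ccccc1F)N1CCOc2c(N3CCNCC3)cc(Cl)cc21` has not yet been measured. It differs from compound 3 in one place: 2-fluorophenyl in place of quinolin-8-yl on a sulfonyl sulfur. Nothing directly comparable has been measured, so the size of this step is uncertain. The two compounds that carry a single six-membered carbon ring on the sulfonyl sulfur, compound 1 and compound 2, are far weaker than compound 3, though they also differ from it elsewhere. On that basis compound 4 is expected to bind less strongly than compound 3, with a step of a 9.5-fold higher number from compound 3 to compound 4 (0.98 log units; beyond the scatter) that is expected to exceed the scatter. The estimate for compound 4 in this assay is 6 nM, with a likely range from 1.5 nM to 30 nM.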

Compound 4, inhibition constant: 0.398 nM
Beside the measured number, compound 4's estimate is 15-fold (1.18 log units) above it; the measured number lies below the stated range.
By their numbers in this assay, from the lowest: compounds 4 and 3 (each within the scatter of the next); then compounds 1 and 2 (each within the scatter of the next).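

In this assay, putting 2-fluorophenyl in place of quinolin-8-yl on a sulfonyl sulfur gives a 1.6-fold lower number from compound 3 to compound 4 (0.20 log units; within the scatter) and so leaves the two compounds indistinguishable. At this position, then, a single six-membered carbon ring bearing fluorine can fit with binding as strong as that of the larger two-ring group, so such a ring alone does not account for the far higher numbers of compound 1 and compound 2, which differ from compound 4 in more than one place. No measurement at hand says why the two groups match.

As far as these compounds go, whether the fluorine matters stays open, and a plain phenyl, or a methoxy group or a nitrile in place of the fluorine, would test it. What the chlorine on the core contributes is also open, since no pair shown differs in that alone.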